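This account rests on a few compounds, and the source may have more. Where it says the series, first, only, none or still open, it means among the compounds named here.

In a functional assay on BJAB cells (Homo sapiens) for antiproliferative activity, with a stated time of 4 days (a lower number here means that less compound is needed, a higher number that more compound is needed for the effect), three compounds built on the same core have been measured. Compound 1 `CCSc1sc(-n2nc(C)c(Cc3ccccc3[N+](=O)[O-])c2C(=O)O)nc1-c1ccc(Cl)c(Cl)c1` gives 59000 nM. Compound 2 `COc1ccc(-c2c(C)nn(-c3nc(-c4ccc(Cl)c(Cl)c4)c(SC(C)C)s3)c2C(=O)O)cc1` gives 2100 nM, the lowest of the three numbers. Compound 3 `Cc1nn(-c2nc(-c3ccc(Cl)c(Cl)c3)c(SC(C)C)s2)c(C(=O)O)c1-c1ccccc1` gives 3000 nM. Compound 2 stands nearest to compound 3 and furthest from compound 1, and only the gap to compound 1 lies beyond the scatter.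

The step to be followed leads to compound 4 `COc1ccc(C)cc1-c1c(C)nn(-c2nc(-c3ccc(Cl)c(Cl)c3)c(SC(C)C)s2)c1C(=O)O`. Its difference from compound 2 is 2-methoxy-5-methylphenyl in place of 4-methoxyphenyl on an aromatic carbon. Going by the values given here, the only measured step that touches the same aromatic carbon is a 1.4-fold higher number from compound 2 to compound 3 (0.15 log units; within the scatter), where the methoxy group was simply removed; that step stayed within the scatter. Among the compounds with values here, the present change keeps a methoxy group but moves it and adds a methyl group, and no measured pair shows what such a rearrangement does. On this thin basis the step expected in this assay is a 1.2-fold higher number from compound 2 to compound 4 (0.08 log units; within the scatter), that is, no clear change beyond the scatter, with the range kept wide. Compound 4 is therefore estimated at 2500 nM, between 800 nM and 8000 nM.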

Compound 4, half-maximal effective concentration: 9500 nM
Estimate against measurement, compound 4: 3.8-fold (0.58 log units) below, outside the stated range (above it).
By their numbers in this assay, from the lowest: compounds 2 and 3 (each within the scatter of the next); then compound 4; then compound 1.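

In this assay this aromatic carbon does not treat every substituted phenyl group alike: 2-methoxy-5-methylphenyl in place of 4-methoxyphenyl gives a 4.5-fold higher number from compound 2 to compound 4 (0.66 log units; beyond the scatter) and in place of phenyl gives a 3.2-fold higher number from compound 3 to compound 4 (0.50 log units; beyond the scatter) so more compound is needed in both comparisons. Both steps lie beyond the scatter, whereas the earlier 1.4-fold higher number from compound 2 to compound 3 (0.15 log units; within the scatter) stayed within it, so the position responds to some changes on this phenyl ring and not to others. Nothing measured on these groups is at hand to account for the shift.

The change moves the methoxy group and adds a methyl group at once, so the compounds shown cannot tell which of the two carries the step. Also open, on these data alone, is what a phenyl ring bearing an amine or a hydroxy group would give on this carbon.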